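Working notes: alkyl homologation on the core of compound 2

The compounds below may be only part of what the source reports. "The series", "measured", "known", "first", "only" and "open" are said of these compounds alone.

Measured so far in a functional assay on HUVEC cells (Homo sapiens) for inhibition, read by ELISA; on this read-out lower numbers stand for stronger inhibition and higher numbers for weaker inhibition:
compound 1, `[O-][S+](Cc1ccccc1)c1nnc(-c2ccncc2)o1` — 4000 nM
compound 2, `CCc1nnc([S+]([O-])Cc2ncc(C)c(OC)c2C)o1` — 12000 nM
compound 3, `COc1c(C)cnc(C[S+]([O-])c2nnc(-c3ccccc3)o2)c1C` — 7000 nM

Compound 2 gives the highest of the three numbers. Its nearest neighbour is compound 3, reached by a 1.7-fold lower number from compound 2 to compound 3 (0.23 log units; within the scatter), which is inside the usual scatter, so the two are not ordered. Compound 1 sits further off, with the gap to compound 2 beyond the scatter.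

Compound 4, `CCCc1nnc([S+]([O-])Cc2ncc(C)c(OC)c2C)o1`, is not yet measured. It differs from compound 2 by methyl in place of hydrogen on a saturated chain carbon, two bonds along the chain from an aromatic carbon. Read one bond further out, the same difference is ethyl to propyl on the aromatic carbon.

Among the measured compounds shown here, only one measured step touches this aromatic carbon: the swap of phenyl for ethyl from compound 2 to compound 3, a change well within the scatter. For the measured compounds named here, no measured pair adds a single saturated carbon to a chain, so the homologation itself has no direct precedent here. Given that the larger swap at this carbon moved the number by a 1.7-fold lower number from compound 2 to compound 3 (0.23 log units; within the scatter) only, the expected step of a 1.2-fold lower number from compound 2 to compound 4 (0.08 log units; within the scatter) is none beyond the scatter. Compound 4 is therefore estimated at 10000 nM, with a range from 4000 nM to 30000 nM.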

Compound 4, half-maximal inhibitory concentration: 10000 nM
For compound 4 middle estimate and measured number coincide at the digits printed; the range from low to high includes it.
By their numbers in this assay, from the lowest: compounds 1, 3, 4 and 2 (each within the scatter of the next, the first and the last beyond it).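

In this assay, among the compounds shown here, the step of a 1.2-fold lower number from compound 2 to compound 4 (0.08 log units; within the scatter) gives the first direct reading of methyl in place of hydrogen on a saturated chain carbon, two bonds along the chain from an aromatic carbon, and it lies within the scatter, so ethyl to propyl leaves compound 2 and compound 4 unordered. The second new reading, a 1.4-fold higher number from compound 3 to compound 4 (0.15 log units; within the scatter), comes from propyl in place of phenyl on an aromatic carbon and also lies within the scatter, so compound 2, compound 3 and compound 4 cannot be separated, whether the group at this carbon is ethyl, propyl or phenyl. No supporting data accompany these numbers to explain this flat stretch of the series.

The compounds shown leave open whether a longer chain such as hexyl, or a chain ending in an amine or a carboxylic acid, would move the number beyond the scatter at this carbon. Compound 1 differs from compound 2 in more than one place, so its gap to compound 2 cannot be assigned to this position.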